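Swapping the aryl group on the pyrazole nitrogen

The source may hold more compounds than are shown below. What is called first, only, known or untested is meant among the compounds shown, and "the series" means these compounds.

Measured so far:
compound 1, `Cn1ncc2c(NC(=O)NCc3cc(C(F)(F)F)nn3-c3ccc(C(C)(C)C)cc3)cccc21`, with 13.2 nM in an assay on CHO-K1 cells for antagonist activity at transient receptor potential cation channel subfamily V member 1 (Homo sapiens), read by FLIPR and calcium flux, with a stated time of 6 min; a lower number here means a stronger inhibitor, a higher number a weaker inhibitor;
compound 2, `Cn1ncc2c(NC(=O)NCc3cc(C(F)(F)F)nn3-c3ccc(F)c(Cl)c3)cccc21`, with 1.9 nM in this assay.

Both compounds share a urea-linked core and differ only in the aromatic ring that sits on an aromatic nitrogen. Going a 6.9-fold lower number from compound 1 to compound 2 (0.84 log units; beyond the scatter). Compound 2 therefore holds the lowest number of the two shown, with compound 1 the next nearest.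

Compound 3, `Cc1ccc(-n2nc(C(F)(F)F)cc2CNC(=O)Nc2cccc3c2cnn3C)cc1C`, is not yet measured. Relative to compound 2 the change is 3,4-dimethylphenyl in place of 3-chloro-4-fluorophenyl on an aromatic nitrogen. For the measured compounds named here, the only step that bears on this is the one from compound 1 to compound 2, which showed that replacing one aromatic ring here by another moves the number by a modest amount. A step of similar or smaller size is expected for compound 3, most likely toward a somewhat higher number, a 2.4-fold higher number from compound 2 to compound 3 (0.37 log units; beyond the scatter). Compound 3 is thus estimated at 4.5 nM, within 1.5 nM to 13 nM.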

Compound 3, inhibition constant: 3.5 nM
Compound 3: the middle estimate sits 1.3-fold (0.11 log units) above what was measured; low and high end bracket the measured number.
By their numbers in this assay, from the lowest: compounds 2 and 3 (each within the scatter of the next); then compound 1.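

In this assay, putting 3,4-dimethylphenyl in place of 3-chloro-4-fluorophenyl on the aromatic nitrogen gives a 1.8-fold higher number from compound 2 to compound 3 (0.27 log units; within the scatter) and so does not separate the two rings, although one carries chlorine and fluorine and the other two methyl groups. The 3,4-dimethylphenyl ring in place of 4-(tert-butyl)phenyl gives a 3.8-fold lower number from compound 1 to compound 3 (0.58 log units; beyond the scatter) and so shows that, among these three compounds, a ring without any halogen can also beat the 4-(tert-butyl)phenyl compound. No measurement shown explains these differences.

As far as these compounds go, it remains open how the number would respond to a ring bearing an amine or a carboxylic acid, or to a pyridine ring in place of the phenyl ring. Also open, from the compounds shown here alone, is what an unsubstituted phenyl ring or 4-fluorophenyl would give.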